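This account rests on a few compounds, and the source may have more. Where it says the series, first, only, none or still open, it means among the compounds named here.

Of the compounds shown here, two with a shared core have been measured, and they differ in the group attached to the ether oxygen. Compound 1 `CCc1ccc2c(c1)c(=O)c(C(=O)Nc1ccc(Oc3ncnc4[nH]cc(-c5ccccc5)c34)cc1)c(C)n2C` carries a larger group there, and in an assay on isolated protein for inhibition of tyrosine-protein kinase receptor UFO (Homo sapiens), read by FRET and Z'-LYTE, with a stated time of 1.5 h (on this read-out lower numbers stand for stronger inhibition and higher numbers for weaker inhibition), compound 1 gives 105 nM. Compound 2 `CCc1ccc2c(c1)c(=O)c(C(=O)Nc1ccc(Oc3ccnc(N)c3)c(F)c1)c(C)n2C` carries a 2-aminopyridin-4-yl group on that oxygen and also carries a fluorine; in this assay compound 2 gives 888 nM. Of the two numbers, compound 2 stands at the higher one, and its gap to compound 1 lies beyond the usual scatter of repeated measurements. Among the compounds with values here, the two measured compounds differ in more than one place, and no single step between them has been isolated.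

Compound 3 `CCc1ccc2c(c1)c(=O)c(C(=O)Nc1ccc(Oc3ccnc(C(N)=O)c3Cl)c(F)c1)c(C)n2C` has not yet been measured. It keeps the core and the fluorine of compound 2 and changes only the group on the oxygen: a group of 10 heavy atoms (6 carbon, 2 nitrogen, 1 oxygen, 1 chlorine; one six-membered aromatic ring with 1 hetero atom) in place of a group of 7 heavy atoms (5 carbon, 2 nitrogen; one six-membered aromatic ring with 1 hetero atom), on an oxygen on an aromatic ring. Within the data shown here, with no measured step of this kind to rest on, the expectation is a moderate lowering of the number, a step of a 2.2-fold lower number from compound 2 to compound 3 (0.35 log units; beyond the scatter), which might still fall within the scatter. Compound 3 is thus expected to give about 400 nM, with a likely range from 120 nM to 1300 nM.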

Compound 3, half-maximal inhibitory concentration: > 10000 nM
Compound 3 ended at the assay's limit; the forecaster's own chance of this, stated with the estimate: 2%; middle value at least 25-fold (1.39 log units) from the limit.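

In this assay, replacing the 2-aminopyridin-4-yl group on the oxygen with the larger chlorine-bearing group of compound 3 gives an at least 11-fold higher number from compound 2 to compound 3 (1.05 log units; beyond the scatter). Within the data shown here, this is the first measured change confined to a single place in this set: the core and the fluorine stay the same, so the loss of inhibition can be traced to the group on this oxygen, and the step lies beyond the usual scatter. For compound 3, the value > 10000 nM is a limit of the assay and not a number: the limit of > 10000 nM in this assay, at which 1 of the 3 values shown sits.

The incoming group differs from the 2-aminopyridin-4-yl group in more than one feature, as it carries both a chlorine and an amide, and the compounds shown cannot separate the part played by each. How the number would respond to a hydrogen in place of that chlorine, or to a carboxylic acid in place of that amide, remains an open question.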